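This account rests on a few compounds, and the source may have more. Where it says the series, first, only, none or still open, it means among the compounds named here.

Measured so far:
Compound 1, `CCN(C(=O)CC(CC(=O)NCCN1CCCCC1)c1ccc(Cl)cc1)C1Cc2ccccc2C1`: 21200 nM
Compound 2, `CCN(C(=O)CC(CC(=O)NCCN1CCCC1)c1ccc(Cl)cc1)C1Cc2ccccc2C1`: 55500 nM

Both compounds were tested in a functional assay on MGC-803 cells (Homo sapiens) for inhibition; a higher number here means a weaker inhibitor, a lower number a stronger inhibitor. Of the two numbers, compound 2 has the higher one, so it is the weaker inhibitor of the pair. Going by the values given here, the single measured step, a 2.6-fold higher number from compound 1 to compound 2 (0.42 log units; beyond the scatter), is modest yet beyond the usual scatter.

The next compound, compound 3, `CN(C(=O)CC(CC(=O)NCCN1CCCC1)c1ccc(Cl)cc1)C1Cc2ccccc2C1`, has not yet been measured. It differs from compound 2 by hydrogen in place of methyl on a saturated chain carbon bound to an amide-type nitrogen. Among the compounds with values here, no measured step probes this kind of change: the one step known alters a different part of the molecule, so it gives no direct guide here. Removing a single carbon from a small alkyl group on an amide-type nitrogen is a small structural change, and without evidence either way the working expectation is a step that stays within the scatter. The estimated step of a 1.0-fold lower number from compound 2 to compound 3 (0.00 log units; within the scatter) is therefore expected to be small. The estimated value for compound 3 is 55000 nM, with a range from 22000 nM to 140000 nM.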

Compound 3, half-maximal inhibitory concentration: 83800 nM
For compound 3 the middle estimate is 1.5-fold (0.18 log units) below the measured one; low and high end bracket the measured number.
By their numbers in this assay, from the lowest: compound 1; then compounds 2 and 3 (each within the scatter of the next).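

In this assay, trimming the ethyl group on the amide-type nitrogen down to methyl gives a 1.5-fold higher number from compound 2 to compound 3 (0.18 log units; within the scatter), so compounds 2 and 3 cannot be told apart and this change has no clear effect on the reading. Going by these compounds alone, this is the first look at this position, since the earlier step changed the ring at the far end of the other chain, and that change, a 2.6-fold higher number from compound 1 to compound 2 (0.42 log units; beyond the scatter), did go beyond the scatter. Within this small set, then, removing one carbon here matters less clearly than swapping piperidin-1-yl for pyrrolidin-1-yl, though no data are available to explain either result.

The compounds shown carry only ethyl and methyl at this place, so they leave open how a longer chain such as propyl, a small ring such as cyclopropyl, or a bare amide hydrogen would behave there. They also leave open whether the swap from ethyl to methyl would read the same way with piperidin-1-yl at the far end of the other chain, as in compound 1, instead of pyrrolidin-1-yl.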